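Where the chlorine sits: from compound 3 to compound 4

A few compounds are considered here, and "the series" means these few. Any claim that something is new, unique, unknown or untested is made for them only; others in the source may bear on it.

compound 1, `Cc1ccc(Nc2nc(C)c(C(=O)/C=C/c3ccc(Cl)cc3)s2)cc1`, which in a functional assay on NCI-H460 cells (Homo sapiens) for cytotoxicity, read by MTT assay (a higher number here means a weaker inhibitor, a lower number a stronger inhibitor), gives only the limit > 25000 nM.
compound 2, `Cc1cccc(Nc2nc(C)c(C(=O)/C=C/c3ccc(Cl)cc3)s2)c1`, which in this assay gives only the limit > 25000 nM.
compound 3, `Cc1ccccc1Nc1nc(C)c(C(=O)/C=C/c2ccccc2Cl)s1`, which in this assay gives only the limit > 25000 nM.

Compound 3 stands where every measured compound stands: at the limit of this assay, and the same holds for the two other values, as the limit of > 25000 nM in this assay, at which 3 of the 3 values shown sit, records. Within the data shown here, the one step between measured compounds, a step that the two limits leave unreadable from compound 1 to compound 2, cannot be read, because both ends are limits, and it concerns a different part of the molecule, so it does not bear on the change examined here.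

Compound 4, `Cc1ccccc1Nc1nc(C)c(C(=O)/C=C/c2ccc(Cl)cc2)s1`, differs from compound 3 in one place: 4-chlorophenyl in place of 2-chlorophenyl on a double-bonded chain carbon bound to a double-bonded chain carbon. Compounds 1 and 2 already carry the 4-chlorophenyl on the same chain carbon, and each of them sits at the limit, so the data give no sign that this group lifts the potency into the readable range.

Compound 4 is therefore expected to give 30000 nM, with a range from 12000 nM to 100000 nM. The step that the limit leaves unreadable from compound 3 to compound 4 is expected to show no change beyond the scatter, with the result most likely again reported only as a limit.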

Compound 4, half-maximal inhibitory concentration: > 25000 nM
Compound 4: only a limit was reported; the forecaster's own chance of this, stated with the estimate: 80%; the middle value does not contradict the limit.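

Compound 4 is recorded only as a limit, as are compounds 1, 2 and 3, so none of the steps from those three to compound 4 can be read: the limit of > 25000 nM in this assay, at which 4 of the 4 values shown sit.

The compounds shown leave open whether the place of the chlorine or of the methyl matters at all in this assay.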